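Swapping the Amide Group: Compound 2 to Compound 3

The source may hold more compounds than are shown below. What is called first, only, known or untested is meant among the compounds shown, and "the series" means these compounds.

Compound 1 `COc1ccc2c(=O)c(/C=C/C(=O)NCc3ccccc3)coc2c1` gives 13600 nM
Compound 2 `COc1ccc2c(=O)c(/C=C/C(=O)Nc3cc(C)ccc3C)coc2c1` gives 11100 nM

In a functional assay on Huh-7 cells (Homo sapiens) for inhibition, read by MTT assay, with a stated time of 48 h (a lower number here means a stronger inhibitor, a higher number a weaker inhibitor), compound 2 gives 11100 nM, and compound 1 stands within the usual scatter of it, so neither counts as the stronger inhibitor. Compound 3 `COc1ccc2c(=O)c(/C=C/C(=O)NCc3cccc(F)c3)coc2c1` shares their core and differs from compound 2 as follows: 3-fluorobenzyl in place of 2,5-dimethylphenyl on an amide-type nitrogen. In words, it has 3-fluorobenzyl in place of 2,5-dimethylphenyl on an amide-type nitrogen. Among the measured compounds shown here, the one measured step, a 1.2-fold lower number from compound 1 to compound 2 (0.09 log units; within the scatter), exchanged benzyl for 2,5-dimethylphenyl at this same nitrogen and changed little. For the measured compounds named here, no measurement yet shows what the added fluorine does. A step beyond the scatter is therefore not expected, and the estimated step is a 1.1-fold higher number from compound 2 to compound 3 (0.05 log units; within the scatter) in this assay. The estimate for compound 3 is 12500 nM, within an expected range from 6000 nM to 25000 nM.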

Compound 3, half-maximal inhibitory concentration: 10100 nM
The estimate for compound 3 lay 1.2-fold (0.09 log units) above the measured number; measured number inside the range.
By their numbers in this assay, from the lowest: compounds 3, 2 and 1 (each within the scatter of the next).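

In this assay, among the compounds shown here, fluoro in place of hydrogen on an aromatic carbon gives a 1.3-fold lower number from compound 1 to compound 3 (0.13 log units; within the scatter) and is the first reading of this change, which stays within the scatter. Putting 3-fluorobenzyl in place of 2,5-dimethylphenyl on the amide-type nitrogen gives a 1.1-fold lower number from compound 2 to compound 3 (0.04 log units; within the scatter), also within the scatter, so benzyl, 2,5-dimethylphenyl and 3-fluorobenzyl cannot be told apart at this nitrogen in this assay. No supporting evidence is available to explain this flat result.

On these data alone, all three groups carry one six-membered aromatic ring of carbon only, so it remains open whether a ring bearing an amine or a carboxylic acid would give a step beyond the scatter. A longer chain between the nitrogen and the ring is equally untested by the compounds shown here.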